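A few compounds are considered here, and "the series" means these few. Any claim that something is new, unique, unknown or untested is made for them only; others in the source may bear on it.

Working notes on the series. In a functional assay on HL-60 cells (Homo sapiens) for antiproliferative activity, read by sulforhodamine B assay, with a stated time of 72 h (a lower number here means a stronger inhibitor, a higher number a weaker inhibitor), compound 2 `N#Cc1ccc(NC(=S)N/N=C/c2ccc3ccccc3n2)cc1` gives 4660 nM, the higher of the two numerical values, while compound 1 `CN(C)C(=S)N/N=C/c1ccc2cccnc2n1` gives 560 nM. Compound 3 `NC(=S)N/N=C/c1ccc2cccnc2n1` gives > 100000 nM, which is a limit of the assay. Next is compound 4 `S=C(N/N=C/c1ccc2ccccc2n1)Nc1ccccc1Br`, with 2-bromophenyl in place of 4-cyanophenyl on an amide-type nitrogen. Among the measured compounds shown here, the one measured step, an at least 170-fold higher number from compound 1 to compound 3 (2.25 log units; beyond the scatter), is large, but it concerns amino in place of dimethylamino on a thiocarbonyl carbon, so it gives no direction for this exchange. No step beyond the scatter is therefore expected in this assay, and the estimated step is a 1.6-fold lower number from compound 2 to compound 4 (0.19 log units; within the scatter). For compound 4 the expected value is 3000 nM, with an estimated range from 600 nM to 15000 nM.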

Compound 4, half-maximal inhibitory concentration: > 100000 nM
Compound 4: no number, only a limit (the forecaster's own chance of this, stated with the estimate: 8%); middle value at least 33-fold (1.52 log units) away from the limit.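

On the amide-type nitrogen, in this assay, the aryl group is not freely exchangeable: 2-bromophenyl in place of 4-cyanophenyl gives an at least 21-fold higher number from compound 2 to compound 4 (1.33 log units; beyond the scatter). Among the compounds shown here, the earlier step concerned only amino in place of dimethylamino on a thiocarbonyl carbon, so this is the first reading on the aryl group at this nitrogen. Compound 4 gives a limit of the assay and not a number, so the step has a lower bound only: the limit of > 100000 nM in this assay, at which 2 of the 4 values shown sit.

The compounds shown do not tell whether the change follows the loss of the nitrile, the entry of bromine, or the placing of either group on the phenyl ring. Plain phenyl, 4-bromophenyl and 2-cyanophenyl on this nitrogen are not among them.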